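Saturating the vinyl end of compound 2

A few compounds are considered here, and "the series" means these few. Any claim that something is new, unique, unknown or untested is made for them only; others in the source may bear on it.

Among the compounds with values here, compound 2 `C=CCCCCCC#CC#CC(O)CC(C)=O` is one of three compounds measured in a functional assay on SK-OV-3 cells (Homo sapiens) for cytotoxicity; a higher number here means that more compound is needed for the effect, a lower number that less compound is needed. Compound 1 `C=CCCCCCC#CC#CCO` gives 9.79 ug/mL, compound 2 gives 3.85 ug/mL, and compound 3 `C=CCCCCCCCC#CC#CCO` gives 3.23 ug/mL. Compound 2 stands second highest of the three; its number is within the scatter of that of compound 3, and beyond the scatter of that of compound 1, as the step of a 2.5-fold lower number from compound 1 to compound 2 (0.41 log units; beyond the scatter) shows.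

Compound 4 `CCCCCCCC#CC#CC(O)CC(C)=O` is not yet measured. Its change from compound 2 is ethyl in place of vinyl on a saturated chain carbon, five bonds along the chain from a triple-bonded carbon, so the double bond of the vinyl is lost and an ethyl is left. Within the data shown here, no measured step tests the same kind of change. The two steps that exist alter other places: a 2.5-fold lower number from compound 1 to compound 2 (0.41 log units; beyond the scatter) adds the 2-oxopropyl, and a 3.0-fold lower number from compound 1 to compound 3 (0.48 log units; beyond the scatter) lengthens vinyl to but-3-en-1-yl while keeping the double bond. Both are modest, and neither speaks to removing the double bond alone.

He therefore expects compound 4 to sit close to compound 2, with a 1.0-fold lower number from compound 2 to compound 4 (0.01 log units; within the scatter) not beyond the scatter. For compound 4 the estimate in this assay is 3.8 ug/mL, with a range from 1.8 ug/mL to 8 ug/mL.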

Compound 4, concentration for half-maximal effect: 1.81 ug/mL
Compound 4: middle estimate off by 2.1-fold (0.32 log units), on the high side; low and high end bracket the measured number.
By their numbers in this assay, from the lowest: compounds 4, 3 and 2 (each within the scatter of the next, the first and the last beyond it); then compound 1.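

Here the double bond of the vinyl is tested on its own for the first time, and in this assay replacing vinyl with ethyl, on a saturated chain carbon, five bonds along the chain from a triple-bonded carbon, gives a 2.1-fold lower number from compound 2 to compound 4 (0.33 log units; beyond the scatter) as a modest change. The earlier steps shown here altered the 2-oxopropyl place or lengthened the vinyl to but-3-en-1-yl with the double bond kept, whereas this one shows that, with the 2-oxopropyl in place, the activity of compound 4 does not depend on that double bond and the number does not rise when it is lost. Nothing available explains why the saturated chain gives the lower number.

The compounds shown leave open whether the same change would give a similar step in compound 1 or compound 3, which lack the 2-oxopropyl, since that change appears here in one pair only. They also leave open how far the chain at this place can be altered, for instance by a longer chain such as butyl or by an amine or a carboxylic acid placed on it.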